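Pyridinylmethylamino group on compound 2: expected effect

This account rests on a few compounds, and the source may have more. Where it says the series, first, only, none or still open, it means among the compounds named here.

In a functional assay on U2OS cells (Homo sapiens) for inhibition, read by CCK-8 assay, with a stated time of 4 days (on this read-out lower numbers stand for stronger inhibition and higher numbers for weaker inhibition), compound 2 `COc1cc(C(=O)O)ccc1NC(=O)[C@@H]1N[C@@H](CC(C)(C)C)[C@](C)(c2ccc(Cl)cc2F)[C@H]1c1cccc(Cl)c1F` gives 640 nM and compound 1 `COc1cc(C(=O)O)ccc1NC(=O)[C@@H]1N[C@@H](CC(C)(C)C)[C@](CNCc2ccc(O)cc2)(c2ccc(Cl)cc2F)[C@H]1c1cccc(Cl)c1F` gives 500 nM. Among the measured compounds shown here, these two values lie within the scatter of each other, so compound 2 stands level with the only other measured member of the series.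

Compound 3 `COc1cc(C(=O)O)ccc1NC(=O)[C@@H]1N[C@@H](CC(C)(C)C)[C@](CNCc2ccccn2)(c2ccc(Cl)cc2F)[C@H]1c1cccc(Cl)c1F` departs from compound 2 by ((pyridin-2-yl)methyl)amino in place of hydrogen on a saturated chain carbon bound to a saturated ring carbon. For the measured compounds named here, one measured step bears on this change: a 1.3-fold higher number from compound 1 to compound 2 (0.11 log units; within the scatter), which exchanges (4-hydroxybenzyl)amino for hydrogen on that same carbon. Going by the values given here, no measured compound carries the pyridine ring, so this comparison is only a partial guide. No change beyond the scatter is therefore expected in this assay. The expected size of the change is a 1.2-fold lower number from compound 2 to compound 3 (0.09 log units; within the scatter). Compound 3 is estimated at 520 nM, with an expected range of 230 nM to 1200 nM.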

Compound 3, half-maximal inhibitory concentration: 820 nM
Beside the measured number, compound 3's estimate is 1.6-fold (0.20 log units) below it, within the range that was stated.
By their numbers in this assay, from the lowest: compounds 1, 2 and 3 (each within the scatter of the next).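

In this assay the step reads a 1.3-fold higher number from compound 2 to compound 3 (0.11 log units; within the scatter), so a second substituent on this saturated chain carbon bound to a saturated ring carbon, this time carrying a pyridine ring, also stands level with compound 2. Placing pyridin-2-yl in place of 4-hydroxyphenyl on a saturated chain carbon bound to an amine nitrogen gives a 1.6-fold higher number from compound 1 to compound 3 (0.21 log units; within the scatter), so these two aromatic groups are not told apart by this read-out, and the position has so far shown no step beyond the scatter. No supporting measurement bears on why these values sit level.

Still open, on these data alone, is whether any group at this position can move the number beyond the scatter; a carboxylic acid or a longer chain carrying the pyridin-2-yl would test this. Also open, as far as these compounds go, is what the amine nitrogen contributes, which an ether oxygen in its place would address.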